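The compounds below may be only part of what the source reports. "The series", "measured", "known", "first", "only" and "open" are said of these compounds alone.

Working notes on the series. Compound 1 `Cc1ccccc1Nc1nc(C)c(C(=O)/C=C/c2ccc(Cl)cc2)s1` has been tested in a functional assay on NCI-H460 cells (Homo sapiens) for cytotoxicity, read by MTT assay; on this read-out lower numbers stand for stronger inhibition and higher numbers for weaker inhibition; compound 1 gives > 25000 nM, which is a limit of the assay and not a number. Compound 2 `Cc1ccccc1Nc1nc(C)c(C(=O)/C=C/c2ccccc2)s1` in this assay gives > 25000 nM, again a limit. Compound 3 `Cc1ccc(Nc2nc(C)c(C(=O)/C=C/c3ccccc3Cl)s2)cc1` in this assay gives > 25000 nM, also a limit. Every measured member therefore sits at the limit of > 25000 nM in this assay, at which 3 of the 3 values shown sit, and compound 3 stands exactly there, with no number of its own to rank it against the other two.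

Within the data shown here, the one step joining measured compounds, a step that the two limits leave unreadable from compound 1 to compound 2, is unreadable, since both ends rest on the limit. It gives no size and no direction to carry forward.

Compound 4 `Cc1ccccc1Nc1nc(C)c(C(=O)/C=C/c2ccccc2Cl)s1` is the next congener to be tested. It differs from compound 3 by 2-methylphenyl in place of 4-methylphenyl on a nitrogen on an aromatic ring; the rest of the shared core, including the chloro on the aromatic carbon of the side arm, is unchanged. Among the measured compounds shown here, with all three measured values at the limit, there is no measured step bearing on this change that can be read, and the working expectation is that compound 4 will also be reported at the limit rather than as a number. Compound 4 is estimated at 40000 nM, with a range from 15000 nM to 120000 nM. The step that the limit leaves unreadable from compound 3 to compound 4 is expected to stay within the scatter, with nothing in the measured set pointing either way.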

Compound 4, half-maximal inhibitory concentration: > 25000 nM
Compound 4 was reported as a limit (the forecaster's own chance of this, stated with the estimate: 85%); the middle value lies beyond the limit too.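

The steps from compound 1, compound 2 and compound 3 to compound 4 cannot be read, since both ends of each rest on a limit: the limit of > 25000 nM in this assay, at which 4 of the 4 values shown sit.

The compounds shown leave open whether the methyl or chloro placement has any effect on the values in this assay.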